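The source may report more compounds than this note shows. Statements on the series, on what has been measured and on what is new or still open speak of the compounds shown alone.

Measured so far in an in vitro assay on BHK cells for binding affinity to gastric inhibitory polypeptide receptor (Homo sapiens); a higher number here means a weaker inhibitor, a lower number a stronger inhibitor:
- compound 1 `O=C(O)CCNC(=O)c1ccc(CN(c2ccc(Cl)cc2)c2nc(-c3ccc(OC(F)(F)F)cc3)cs2)cc1` gives 460 nM
- compound 2 `O=C(O)CCNC(=O)c1ccc(CN(c2ccc3c(c2)CCCC3)c2nc(-c3ccc(Cl)c(Cl)c3)cs2)cc1` gives 390 nM
- compound 3 `Cc1cc(N(Cc2ccc(C(=O)NCCC(=O)O)cc2)c2nc(-c3ccc(C(F)(F)F)cc3)cs2)ccc1C(C)C` gives 293 nM

Compound 3 returns the lowest of the three numbers in this assay, but its gap to compound 2 and its gap to compound 1 both lie within the usual scatter, so the three compounds cannot be separated from one another on these data. Among the compounds with values here, no step between measured compounds that differ in a single place is available, so there is no measured precedent for any single change.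

Compound 4 `O=C(O)CCNC(=O)c1ccc(CN(c2ccc(OC(F)(F)F)cc2)c2nc(-c3ccc(C(F)(F)F)cc3)cs2)cc1` differs from compound 3 at one site: 4-(trifluoromethoxy)phenyl in place of 4-isopropyl-3-methylphenyl on a nitrogen on an aromatic ring. The same 4-(trifluoromethoxy)phenyl group appears elsewhere in compound 1, on the shared core rather than at this nitrogen, and compound 1 sits within the scatter of compound 3. With three near-identical numbers across varied groups at both aryl positions, the expectation for a 1.4-fold higher number from compound 3 to compound 4 (0.14 log units; within the scatter) is a step of no size beyond the scatter, in no firm direction. Compound 4 is therefore estimated at 400 nM, with a range from 150 nM to 1100 nM.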

Compound 4, half-maximal inhibitory concentration: 480 nM
The estimate for compound 4 lay 1.2-fold (0.08 log units) below the measured number; the range from low to high includes it.
By their numbers in this assay, from the lowest: compounds 3, 2, 1 and 4 (each within the scatter of the next).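

In this assay, within the data shown here, the change to 4-(trifluoromethoxy)phenyl in place of 4-isopropyl-3-methylphenyl gives a 1.6-fold higher number from compound 3 to compound 4 (0.21 log units; within the scatter) and provides the first single-site step. On these two compounds, this place on a nitrogen on an aromatic ring carries an all-carbon substituted phenyl and a phenyl bearing oxygen and fluorine without any separation in the read-out, even though the entering group adds a hydrogen-bond acceptor. Nothing measured here bears on the reason for this result.

As far as these compounds go, whether a saturated group such as cyclohexyl, or a phenyl carrying an amine or a carboxylic acid, at this nitrogen would give a step beyond the scatter remains open. Also open, from the compounds shown here alone, is whether the same change reads alike with a group other than the 4-(trifluoromethyl)phenyl shared by compound 3 and compound 4 on the core.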